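Tetrachlorocyclopentadienylidene series: hydrazone to oxime step

The compounds below may be only part of what the source reports. "The series", "measured", "known", "first", "only" and "open" are said of these compounds alone.

Notes on the series. Compound 1, `Fc1cccc(NN=C2C(Cl)=C(Cl)C(Cl)=C2Cl)c1`, and compound 2, `CN(C)N=C1C(Cl)=C(Cl)C(Cl)=C1Cl`, share a core, and compound 3, `ON=C1C(Cl)=C(Cl)C(Cl)=C1Cl`, is the next member awaiting measurement. In a functional assay on RPMI-8226 cells (Homo sapiens) for cytotoxicity, read by MTT assay, with a stated time of 48 h (a higher number here means a weaker inhibitor, a lower number a stronger inhibitor), compound 1 gives 500 nM. For compound 2 this assay reports only a limit, >= 1300 nM, not a number. Going by the values given here, compound 2 therefore stands at the limit of >= 1300 nM in this assay, at which 1 of the 2 values shown sits, the weaker end of what has been measured, while compound 1 is the only member with a defined value. Among the compounds with values here, no step between measured compounds can be drawn, so the size of the change from the hydrazone of compound 2 to the oxime of compound 3 has no precedent.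

The change is hydroxy in place of dimethylamino on a double-bonded nitrogen. Compound 3 is expected to stay near the limit region where compound 2 sits, with a step that the limit leaves unreadable from compound 2 to compound 3 in this assay that is unlikely to exceed the scatter in either direction. The estimate for compound 3 in this assay is 2000 nM, within a range from 600 nM to 7000 nM, and a limit-only read-out is plausible.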

Compound 3, half-maximal inhibitory concentration: > 5000 nM
Compound 3 gave a limit, no number; the forecaster's own chance of this, stated with the estimate: 50%; middle value at least 2.5-fold (0.39 log units) from the limit.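

In this assay compound 3 gives > 5000 nM as a limit, not a number. In this assay compound 2 gives >= 1300 nM as a limit as well. Going by these compounds alone, no step between compound 2 and compound 3 can be read. The compounds shown leave open the size of the change on placing hydroxy in place of dimethylamino on a double-bonded nitrogen.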